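The compounds below may be only part of what the source reports. "The series", "measured", "known", "first", "only" and "open" are said of these compounds alone.

Compound 1, `N#CC1=C(NC(=O)c2ccccc2O)N(c2ccccc2)C(=O)N2CCCCC(N3CCCC3)C12`, gives 65.4% in a functional assay on the whole organism (strain albino) for inhibition, with Rattus norvegicus as the target, read by paw edema, with stated times of 1 h and 3 h, at a dose of 20 mmol/kg by the intraperitoneal route; on this read-out lower numbers stand for a weaker effect and higher numbers for a stronger effect at the one dose given.
Compound 2, `COC(=O)C(=O)NC1=C(C#N)C2C(N3CCCC3)CCCCN2C(=O)N1c1ccccc1`, gives 88.3% in this assay.
Compound 3, `N#CC1=C(NCC(=O)O)N(c2ccccc2)C(=O)N2CCCCC(N3CCCC3)C12`, gives 89.2% in this assay.

Compound 2 stands second highest of the three numbers in this assay. Its nearest neighbour is compound 3, which differs by a number 0.9 percentage points higher from compound 2 to compound 3 (within the scatter), a gap within the scatter; its furthest is compound 1, which lies below it by a number 22.9 percentage points higher from compound 1 to compound 2 (beyond the scatter), a gap beyond the scatter.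

Compound 4, `N#CC1=C(NCC(=O)N2CCCC2)N(c2ccccc2)C(=O)N2CCCCC(N3CCCC3)C12`, has not yet been measured. It differs from compound 2 in one place: ((pyrrolidin-1-yl)carbonyl)methyl in place of (methoxycarbonyl)carbonyl on an amine nitrogen.

Going by the values given here, two measured steps bear on this change. The step of a number 0.9 percentage points higher from compound 2 to compound 3 (within the scatter) removes the same (methoxycarbonyl)carbonyl group from the same amine nitrogen and puts a carboxymethyl group in its place, and that exchange stayed within the scatter. The step of a number 23.8 percentage points higher from compound 1 to compound 3 (beyond the scatter) shows that replacing the (2-hydroxyphenyl)carbonyl group on that nitrogen with carboxymethyl raised the number by a modest amount. Among the compounds with values here, since the nitrogen already carries a group that gives a high number in compound 2, and the one exchange on this nitrogen that was measured from compound 2 stayed within the scatter, compound 4 is expected to show a step of a number 4.3 percentage points lower from compound 2 to compound 4 (within the scatter), not beyond the scatter. Compound 4 is therefore estimated at 84%, with a range from 68% to 95%.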

Compound 4, a percentage reported as inhibition, in the whole organism at one dose (the size of the read-out at that dose, not a potency): 56%
The estimate for compound 4 lay 28 percentage points above the measured number; the whole stated range lies above it.
By their numbers in this assay, from the lowest: compounds 4 and 1 (each within the scatter of the next); then compounds 2 and 3 (each within the scatter of the next).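

The change on this amine nitrogen turns out to depend strongly on the group that enters: in this assay the exchange for carboxymethyl stayed level with a number 0.9 percentage points higher from compound 2 to compound 3 (within the scatter) as its step, whereas the exchange for ((pyrrolidin-1-yl)carbonyl)methyl gives a number 32.3 percentage points lower from compound 2 to compound 4 (beyond the scatter) and so takes away the high number. The closest comparison is the one that alters only the end of the chain, since a number 33.2 percentage points lower from compound 3 to compound 4 (beyond the scatter) follows from pyrrolidin-1-yl in place of hydroxy on a carbonyl carbon, so the high number of compound 3 does not carry over to every group with this chain on the nitrogen. The step to the aryl-bearing compound, a number 9.4 percentage points lower from compound 1 to compound 4 (within the scatter) in this reading, places the new group level with (2-hydroxyphenyl)carbonyl, so two quite different groups on this nitrogen give numbers within the scatter of each other.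

Nothing given here accounts for the loss seen with the pyrrolidin-1-yl group. The compounds shown leave open how a methyl ester or an unsubstituted amide on the same carbonyl carbon would read, and whether a longer chain carrying the carboxylic acid would keep the high number.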